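Replacing Fluoro with Bromo: Expected Effect on Cell Growth

The source may hold more compounds than are shown below. What is called first, only, known or untested is meant among the compounds shown, and "the series" means these compounds.

Measured so far:
compound 1 `COc1cc(OC)c(C(=O)/C=C/c2ccccc2SC)c(OC)c1` gives 3%
compound 2 `COc1cccc(/C=C/C(=O)c2c(OC)cc(OC)cc2OC)c1` gives 5.1%
compound 3 `COc1cc(OC)c(C(=O)/C=C/c2ccc(F)cc2)c(OC)c1` gives 4.5%

All three numbers come from a functional assay on NCI-H727 cells (Homo sapiens), read by fluorescence and BrdU incorporation, with a stated time of 48 h, tested at 25 uM; a higher number here means a weaker effect of the compound at the concentration tested, a lower number a stronger effect. Compound 3 stands second highest of the three, closest to compound 2 and furthest from compound 1, yet every one of these gaps lies within the scatter, so the three compounds cannot be told apart on the read-out.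

Compound 4 `COc1cc(OC)c(C(=O)/C=C/c2ccc(Br)cc2)c(OC)c1` has not yet been measured. It differs from compound 3 by a single change: bromo in place of fluoro on an aromatic carbon. The spot concerned is para to a large group, and a bromo replaces a fluoro there.

Among the measured compounds shown here, no measured step exchanges one halogen for another. The steps that touch the same aryl ring are a number 0.6 percentage points lower from compound 2 to compound 3 (within the scatter) and a number 1.5 percentage points higher from compound 1 to compound 3 (within the scatter), and both exchange the whole group on that ring for a very different one without moving the number beyond the scatter. A swap of fluoro for bromo at the same spot is a smaller change than either, so no step beyond the scatter is expected in this assay: the expected step is no change at the digits printed from compound 3 to compound 4 (within the scatter).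

Compound 4 is therefore estimated at 4.5%, with a range from 0% to 15%.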

Compound 4, a percentage reported as activity, at one concentration (the size of the read-out at that concentration, not a potency): 6%
Compound 4: middle estimate off by 1.5 percentage points, on the low side, within the range that was stated.
By their numbers in this assay, from the lowest: compounds 1, 3, 2 and 4 (each within the scatter of the next).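

In this assay, among the compounds shown here, bromo in place of fluoro on an aromatic carbon, para to a large group, gives a number 1.5 percentage points higher from compound 3 to compound 4 (within the scatter) and so provides the first direct reading of one halogen exchanged for another at this spot. The 4-bromophenyl group also cannot be told apart from the other two aryl groups: 4-bromophenyl in place of 3-methoxyphenyl gives a number 0.9 percentage points higher from compound 2 to compound 4 (within the scatter) and 4-bromophenyl in place of 2-(methylsulfanyl)phenyl gives a number 3 percentage points higher from compound 1 to compound 4 (within the scatter), which means that fluoro and bromo at this spot, like the groups on the aryl rings of compound 1 and compound 2, leave the read-out flat at the one concentration tested. No measurement shown here offers an explanation for this flat picture.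

Because these are readings at one concentration and not potencies, the compounds shown leave open whether fluoro and bromo would still match at lower concentrations, where a difference between them might appear. From the compounds shown here alone, it also remains open whether a group of another kind at the same spot, such as an amine or a carboxylic acid, would stay within the scatter of these four compounds.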